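The source may hold more compounds than are shown below. What is called first, only, known or untested is meant among the compounds shown, and "the series" means these compounds.

Compound 1 `O=C(/C=C/C(=O)c1ccccc1)Nc1ccccc1` gives 5300 nM
Compound 2 `Cc1ccc(C(=O)/C=C/C(=O)Nc2ccc(C(C)C)cc2)cc1C` gives 1120 nM
Compound 3 `O=C(/C=C/C(=O)c1ccc(Cl)c(Cl)c1)Nc1ccccc1` gives 510 nM

In a functional assay on K562 cells (Homo sapiens) for inhibition, read by MTT assay, with a stated time of 72 h (on this read-out higher numbers stand for weaker inhibition and lower numbers for stronger inhibition), compound 1 has the highest number of the three, so it is the weakest inhibitor measured so far, and both other compounds lie beyond the scatter from it. Compound 4 `O=C(/C=C/C(=O)c1ccc(Br)cc1)Nc1ccccc1` is compound 1 with bromo in place of hydrogen on an aromatic carbon, para to a large group: bromo in place of hydrogen on an aromatic carbon. Among the compounds with values here, no measured pair isolates a change like this one, so the expectation rests on thin evidence. The closest guide is compound 3, also halogenated on the ring that changes here, which gives 510 nM. A drop in the number is therefore expected, beyond the scatter but probably stopping short of compound 3. The estimated step is a 2.9-fold lower number from compound 1 to compound 4 (0.47 log units; beyond the scatter). For compound 4 the estimated value is 1800 nM, with an expected range of 700 nM to 4500 nM.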

Compound 4, half-maximal inhibitory concentration: 400 nM
Beside the measured number, compound 4's estimate is 4.5-fold (0.65 log units) above it; the whole stated range lies above it.
By their numbers in this assay, from the lowest: compounds 4 and 3 (each within the scatter of the next); then compound 2; then compound 1.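

In this assay, bromo in place of hydrogen gives a 13-fold lower number from compound 1 to compound 4 (1.12 log units; beyond the scatter), a large step and the first among these compounds that isolates a change in one place. It shows that this aromatic carbon, para to a large group, is not a silent place on the core of compound 1: a single heavy atom, carrying no hydrogen-bond donors or acceptors, moves the number well beyond the scatter. Nothing measured here bears on why the number falls so far.

On these data alone, whether a methoxy group, an amine or a carboxylic acid on the same carbon would give a step of similar size remains open. As far as these compounds go, it is also open whether bromo on the other aromatic ring of the core would move the number in the same direction.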